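Compound 4 Before Measurement: A Halogen Exchange on Compound 2

A few compounds are considered here, and "the series" means these few. Any claim that something is new, unique, unknown or untested is made for them only; others in the source may bear on it.

Of the compounds shown here, three have so far been tested in a functional assay on PC-3 cells (Homo sapiens) for antiproliferative activity, read by MTT assay, tested at 1 uM; a higher number here means a stronger effect of the compound at the concentration tested, a lower number a weaker effect. Compound 1 `COc1cc(C2=NN(C(C)=O)C(c3cccc(F)c3)O2)cc(OC)c1OC` gives 16.5% in this assay. Compound 2 `COc1cc(C(=O)N/N=C/c2ccc(F)c(F)c2)cc(OC)c1OC` gives 35.1% in this assay, the highest of the three numbers: compound 1 lies lower by a margin beyond the usual scatter, and compound 3 `COc1cc(C2=NN(C(C)=O)C(c3cc(OC)c(OC)c(OC)c3)O2)cc(OC)c1OC`, which gives -1.8% in this assay, lies lower still, again beyond the scatter. Compound 4 `COc1cc(C(=O)N/N=C/c2ccc(Cl)c(Cl)c2)cc(OC)c1OC` has not yet been measured. It differs from compound 2 in a single place: 3,4-dichlorophenyl in place of 3,4-difluorophenyl on a carbon with a double bond to nitrogen. Among the measured compounds shown here, no pair of measured compounds shows what this kind of exchange does in this assay, so the direction of the step is not settled by the data at hand. A step of modest size, roughly within the scatter and leaning upward if anywhere, is expected. Compound 4 is therefore expected to give about 38% in this assay, within a range from 20% to 55%. This amounts to an expected step of a number 2.9 percentage points higher from compound 2 to compound 4 (within the scatter).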

Compound 4, a percentage reported as inhibition, at one concentration (the size of the read-out at that concentration, not a potency): 13.5%
For compound 4 the middle estimate is 24.5 percentage points above the measured one; measured number outside the range, below it.
By their numbers in this assay, from the lowest: compound 3; then compounds 4 and 1 (each within the scatter of the next); then compound 2.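

Among the compounds shown here, this pair is the first in the set to isolate a single change, and in this assay it shows that the read-out depends on which halogen the phenyl group carries: 3,4-dichlorophenyl in place of 3,4-difluorophenyl on a carbon with a double bond to nitrogen gives a number 21.6 percentage points lower from compound 2 to compound 4 (beyond the scatter). The two groups have the same count of heavy atoms, the same aromatic ring and no net charge, yet the exchange still moves the number beyond the scatter, so this position is sensitive to the change.

From the compounds shown here alone, it remains open how this position would respond to an unsubstituted phenyl, or to a phenyl carrying bromine, a nitrile or an amine. Nothing measured here explains why the dichloro compound falls short of the difluoro compound.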